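Carboxylate Ester Added to a Second Core

The source may report more compounds than this note shows. Statements on the series, on what has been measured and on what is new or still open speak of the compounds shown alone.

Compound 1 `O=C1C2=C(CCCC2)S(=O)(=O)N1c1ccc(Cl)cc1` and compound 2 `CC(C)OC(=O)c1cc(N2C(=O)C3=C(CCCC3)S2(=O)=O)ccc1Cl` share one core. In a functional assay on the whole organism with Scenedesmus acutus as the target, read by spectrophotometry (a lower number here means a stronger inhibitor, a higher number a weaker inhibitor), compound 1 gives 5250 nM, and compound 2 gives 501 nM. The change between them is isopropoxycarbonyl in place of hydrogen on an aromatic carbon, and it made a step of a 10-fold lower number from compound 1 to compound 2 (1.02 log units; beyond the scatter).

Compound 3 `O=c1c2c(sn1-c1ccc(Cl)cc1F)CCCC2` has a different core; the difference between the two cores is not broken down here. In this assay compound 3 gives 20400 nM. Compound 4 `CC(C)OC(=O)c1cc(-n2sc3c(c2=O)CCCC3)c(F)cc1Cl` differs from compound 3 by isopropoxycarbonyl in place of hydrogen on an aromatic carbon. Compared with the earlier change, the new group also sits para to a fluoro group, so this is the same kind of change, not the same one.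

Among the measured compounds shown here, compound 4 is expected to gain about a 6.8-fold lower number from compound 3 to compound 4 (0.83 log units; beyond the scatter), somewhat smaller than the earlier step, because the only prior example is a 10-fold lower number from compound 1 to compound 2 (1.02 log units; beyond the scatter) on a different core. The estimate for compound 4 is 3000 nM, between 800 nM and 12000 nM.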

Compound 4, half-maximal inhibitory concentration: 7240 nM
The estimate for compound 4 lay 2.4-fold (0.38 log units) below the measured number; measured number inside the range.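

On the second core, the added isopropoxycarbonyl again lowers the number in this assay, giving a 2.8-fold lower number from compound 3 to compound 4 (0.45 log units; beyond the scatter), so the direction of the change carries over between these two cores. The size does not carry over, and the gap between the two steps is larger than repeated measurements would explain: the same change on two cores in this assay, a 10-fold lower number (1.02 log units; beyond the scatter) from compound 1 to compound 2 and a 2.8-fold lower number (0.45 log units; beyond the scatter) from compound 3 to compound 4, 3.7-fold (0.57 log units) apart, beyond the scatter of two such steps. Among the compounds shown here, with only one pair on each core, this does not show why the steps differ, since compounds 3 and 4 differ from compounds 1 and 2 in their core and also carry a fluoro group.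

Going by these compounds, it remains open whether a carboxylic acid or an amide in the same place would behave like the isopropyl ester. On these data alone, it is also open which size of step a third core would give.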